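The compounds below may be only part of what the source reports. "The series", "measured", "known", "first", "only" and "open" are said of these compounds alone.

Working notes on the series. In an ADME assay on the whole organism for pharmacokinetics, with Rattus norvegicus as the target, at a dose of 5 mg/kg by the oral route (on this read-out higher numbers stand for higher exposure at the dose given and lower numbers for lower exposure), compound 1 (`CC(C)(O)c1ccc(-c2cnc3c(n2)N(CC2CCCCC2)CC(=O)N3)cn1`) has no number to stand on, its entry being "not determined" (no result reported). Among the measured compounds shown here, the only measured member is compound 2 (`CC(C)(O)c1ccc(-c2cnc3c(n2)N(CC2CCOCC2)C(=O)CN3)cn1`), at 3800 ng.h/mL. Compound 3 (`CO[C@H]1CC[C@@H](N2CC(=O)Nc3ncc(-c4ccc(C(C)(C)O)nc4)nc32)CC1`) awaits measurement. Its change from compound 1 is 4-methoxycyclohexyl in place of cyclohexylmethyl on a nitrogen on an aromatic ring in a ring: 4-methoxycyclohexyl in place of cyclohexylmethyl. For the measured compounds named here, no measured step exists to size this change, so no step beyond the scatter is expected in this assay, in either direction. The expectation therefore rests on compound 2 at 3800 ng.h/mL. For compound 3 the estimated value is 4000 ng.h/mL, with an expected range of 1200 ng.h/mL to 13000 ng.h/mL.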

Compound 3, area under the concentration-time curve: 10600 ng.h/mL
The estimate for compound 3 lay 2.7-fold (0.42 log units) below the measured number; the range from low to high includes it.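

No step can be read from compound 1 to compound 3 in this assay, as compound 1 has no number there. As far as these compounds go, the effect on exposure of 4-methoxycyclohexyl in place of cyclohexylmethyl stays open, and no evidence bears on this result.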